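Aryl amide in place of alkyne ester at the carbonyl

The compounds below may be only part of what the source reports. "The series", "measured", "known", "first", "only" and "open" are said of these compounds alone.

Measured so far:
compound 1 `CCN(CC)CCNC(=O)c1ccc(C(CC)(CC)c2ccc(OCC(O)C(C)(C)C)c(C)c2)n1CC` — 110 nM
compound 2 `CCN(CC)CCCNC(=O)c1ccc(C(CC)(CC)c2ccc(OCC(O)C(C)(C)C)c(C)c2)n1CC` — 66 nM
compound 3 `C#CCCOC(=O)c1ccc(C(CC)(CC)c2ccc(OCC(O)C(C)(C)C)c(C)c2)n1CC` — 1030 nM

In an assay on HL-60 cells for agonist activity at vitamin D3 receptor (Homo sapiens), read by microscopy, with a stated time of 96 h (on this read-out higher numbers stand for an effect only at larger amounts of compound and lower numbers for an effect already at smaller amounts), compound 3 gives the highest of the three numbers. The two steps that reach it, a 9.4-fold higher number from compound 1 to compound 3 (0.97 log units; beyond the scatter) and a 16-fold higher number from compound 2 to compound 3 (1.19 log units; beyond the scatter), both exchange a diethylamino-bearing amide for the (but-3-yn-1-yl)oxy ester, and both lie beyond the scatter. Compound 4 `CCn1c(C(=O)Nc2cccc(C(F)(F)F)c2)ccc1C(CC)(CC)c1ccc(OCC(O)C(C)(C)C)c(C)c1` now carries the change ((3-(trifluoromethyl)phenyl)amino in place of (but-3-yn-1-yl)oxy on a carbonyl carbon). Among the compounds with values here, it returns to an amide at that carbonyl, yet without the diethylamino chain that compounds 1 and 2 share, so the earlier steps bear on it only in part. A lower number than compound 3 is therefore expected, likely short of compound 1, with compound 4 estimated at 250 nM (range 60 nM to 1000 nM), corresponding to the expected step of a 4.1-fold lower number from compound 3 to compound 4 (0.61 log units; beyond the scatter).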

Compound 4, half-maximal effective concentration: > 50000 nM
Compound 4: only a limit was reported (the forecaster's own chance of this, stated with the estimate: 5%); middle value at least 200-fold (2.30 log units) from the limit.
By their numbers in this assay, from the lowest: compounds 2 and 1 (each within the scatter of the next); then compound 3. At a limit, above all of these: compound 4.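

In this assay the value of compound 4 is a limit and not a number: the limit of > 50000 nM in this assay, at which 1 of the 4 values shown sits. An amide at this carbonyl is therefore not enough on its own, as the group on the amide-type nitrogen matters greatly, with an at least 750-fold higher number from compound 2 to compound 4 (2.87 log units; beyond the scatter) and an at least 450-fold higher number from compound 1 to compound 4 (2.65 log units; beyond the scatter). The ester also gives a lower number than this aryl amide, with an at least 48-fold higher number from compound 3 to compound 4 (1.68 log units; beyond the scatter).

As far as these compounds go, it remains open whether the change in read-out follows from the aromatic ring or from its trifluoromethyl group. A plain phenyl amide or a benzyl amide would help separate the two.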